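Swapping the aryl group in a shared core: clearance outlook

A few compounds are considered here, and "the series" means these few. Any claim that something is new, unique, unknown or untested is made for them only; others in the source may bear on it.

Measured so far in an ADME assay (liver) for metabolic stability, with Liver microsome (Homo sapiens) as the target, using microsomes and NADPH, with a stated time of 30 min, tested at 1 uM; a higher number here means faster removal of the compound, a lower number slower removal:
- compound 1, `CCn1cc(-c2cc(C(O)(C(F)(F)F)C(F)(F)F)cnc2N2CCN(S(=O)(=O)c3ccc(N)nc3)CC2)cn1`: 20 mL.min-1.g-1
- compound 2, `Nc1ccc(S(=O)(=O)N2CCN(c3ncc(C(O)(C(F)(F)F)C(F)(F)F)cc3-c3ccccc3O)CC2)cn1`: 22 mL.min-1.g-1
- compound 3, `Nc1ccc(S(=O)(=O)N2CCN(c3ncc(C(O)(C(F)(F)F)C(F)(F)F)cc3-c3ccc4scnc4c3)CC2)cn1`: 39 mL.min-1.g-1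

These three compounds share one core and differ only in the aryl group attached to it. In this assay compound 2 sits between the other two, but its distance to each of them is small: the step of a 1.1-fold higher number from compound 1 to compound 2 (0.04 log units; within the scatter) is within the scatter, and so is the step of a 1.8-fold higher number from compound 2 to compound 3 (0.25 log units; within the scatter). Among the measured compounds shown here, the remaining step, a 2.0-fold higher number from compound 1 to compound 3 (0.29 log units; within the scatter), is also within the scatter, so no compound here is cleared faster or slower than another in any reliable sense.

Compound 4, `Nc1ccc(S(=O)(=O)N2CCN(c3ncc(C(O)(C(F)(F)F)C(F)(F)F)cc3-c3cc4ccccc4[nH]3)CC2)cn1`, has not yet been measured. Its change from compound 2 is 1H-indol-2-yl in place of 2-hydroxyphenyl on an aromatic carbon.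

For the measured compounds named here, the steps that bear on this are those in which the same aryl position is changed: a 1.1-fold higher number from compound 1 to compound 2 (0.04 log units; within the scatter), a 1.8-fold higher number from compound 2 to compound 3 (0.25 log units; within the scatter) and a 2.0-fold higher number from compound 1 to compound 3 (0.29 log units; within the scatter). None of them moved the number beyond the scatter, whether the incoming group was a single ring or a fused pair of rings. On that basis the expected step of a 1.4-fold higher number from compound 2 to compound 4 (0.13 log units; within the scatter) is none beyond the scatter. For compound 4 the estimated value in this assay is 30 mL.min-1.g-1, with a range from 14 mL.min-1.g-1 to 65 mL.min-1.g-1.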

Compound 4, intrinsic clearance in microsomes: < 14 mL.min-1.g-1
Compound 4: a limit, no number; the forecaster's own chance of this, stated with the estimate: 5%; middle value at least 2.1-fold (0.33 log units) from the limit.
By their numbers in this assay, from the lowest: compounds 1, 2 and 3 (each within the scatter of the next). At a limit, below all of these: compound 4.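

In this assay the reading for compound 4 is a limit of the assay and not a number: the limit of < 14 mL.min-1.g-1 in this assay, at which 1 of the 4 values shown sits. Even so, this aryl position now yields a step that clears the scatter, which none of the earlier swaps did, namely an at least 2.7-fold lower number from compound 3 to compound 4 (0.44 log units; beyond the scatter), so 1H-indol-2-yl and 1,3-benzothiazol-5-yl, though both are fused pairs of rings, are not interchangeable here. The other two steps, an at least 1.5-fold lower number from compound 2 to compound 4 (0.19 log units; that floor lies within the scatter) and an at least 1.4-fold lower number from compound 1 to compound 4 (0.15 log units; that floor lies within the scatter), have floors within the scatter, so they do not yet separate those pairs, although the true gaps may be wider than these floors.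

On these data alone, it stays open whether the result belongs to the hydrogen on the indole nitrogen or to the fused rings as such, a question that a 1-benzofuran-2-yl group, with oxygen in place of that nitrogen, or a 1-methyl-1H-indol-2-yl group would address. Also open, as far as these compounds go, is what a plain phenyl group, without the hydroxyl of the 2-hydroxyphenyl in compound 2, would give at this position.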